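The source may hold more compounds than are shown below. What is called first, only, known or untested is meant among the compounds shown, and "the series" means these compounds.

Compound 1 has the structure `CC(C)=CCC/C(C)=C/CC/C(C)=C/CSC[C@H](NC(=O)OC(C)(C)C)C(=O)CCl` and in a functional assay on MOLT-3 cells (Homo sapiens) (a higher number here means a weaker inhibitor, a lower number a stronger inhibitor), compound 1 gives 7700 nM. Compound 2 has the structure `CC(C)=CCC/C(C)=C/CC/C(C)=C/CSC[C@H](NC(=O)CNC(=O)OC(C)(C)C)C(=O)C=[N+]=[N-]` and in this assay compound 2 gives 84500 nM, the highest of the two numbers recorded and a step beyond the scatter away from compound 1. Within the data shown here, no single-change step between measured compounds is available, so the numbers of compound 1 and compound 2 show only that they lie well apart.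

Compound 3 has the structure `CC(C)=CCC/C(C)=C/CC/C(C)=C/CSC[C@H](NC(=O)CNC(=O)OC(C)(C)C)C(=O)CCl` and has not yet been measured. It differs from compound 2 in one place: a group of 2 heavy atoms (1 carbon, 1 chlorine; no ring) in place of a group of 3 heavy atoms (1 carbon, 2 nitrogen; no ring), on a carbonyl carbon. Compound 3 thus carries the chloromethyl group that compound 1 also carries. Because compound 1 gives 7700 nM with that group, compound 3 is expected to fall well below compound 2, a step from compound 2 to compound 3 of about an 8.5-fold lower number from compound 2 to compound 3 (0.93 log units; beyond the scatter). Compound 3 is estimated at 10000 nM in this assay, within 3000 nM to 40000 nM.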

Compound 3, half-maximal inhibitory concentration: 17500 nM
Compound 3: middle estimate off by 1.8-fold (0.24 log units), on the low side; the range from low to high includes it.
By their numbers in this assay, from the lowest: compound 1; then compound 3; then compound 2.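

Among these compounds, with compound 3, the effect of a single change can be read for the first time. In this assay, chloromethyl in place of the group of 3 heavy atoms (1 carbon, 2 nitrogen) on a carbonyl carbon gives a 4.8-fold lower number from compound 2 to compound 3 (0.68 log units; beyond the scatter), a modest step that shows this position alone affects the number when the rest of the molecule is held constant. A second, separate change also matters with chloromethyl held in place: ((tert-butoxycarbonyl)amino)methyl in place of tert-butoxy on a carbonyl carbon gives a 2.3-fold higher number from compound 1 to compound 3 (0.36 log units; beyond the scatter), likewise modest, and nothing available explains either step.

The compounds shown leave open whether the exchange of the group of 3 heavy atoms for chloromethyl would give a step of similar size with the tert-butoxy group of compound 1 in place. They also leave open how other groups on this carbonyl carbon, such as a fluoromethyl group, a hydroxymethyl group or a simple methyl group, would compare with chloromethyl in this assay.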